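Swapping the Basic Ring on a Shared Side Chain

A few compounds are considered here, and "the series" means these few. Any claim that something is new, unique, unknown or untested is made for them only; others in the source may bear on it.

Compound 1, `COc1cc2c(Oc3ccc(NC(=O)c4cn(-c5ccc(Cl)cc5Cl)cn4)cc3F)ccnc2cc1OCCCN1CCN(C)CC1`, is tested in a functional assay on MKN-45 cells (Homo sapiens) for cytotoxicity, read by MTT assay, with a stated time of 72 h (a lower number here means a stronger inhibitor, a higher number a weaker inhibitor), and gives 4840 nM. Compound 2, `COc1cc2c(Oc3ccc(NC(=O)c4cn(-c5ccc(Cl)cc5Cl)cn4)cc3F)ccnc2cc1OCCCN1CCCCC1`, differs from it by a single change, (piperidin-1-yl in place of 4-methylpiperazin-1-yl on a saturated chain carbon, three bonds along the chain from an oxygen on an aromatic ring), and in this assay compound 2 gives 6240 nM. This gives the step of a 1.3-fold higher number from compound 1 to compound 2 (0.11 log units; within the scatter). Compound 3, `COc1cc2c(Oc3ccc(NC(=O)/C=C/S(=O)(=O)c4ccccc4OC)cc3F)ccnc2cc1OCCCN1CCN(C)CC1`, differs from compound 1 in more than one place, and the difference between the two cores is not broken down here. In this assay compound 3 gives 430 nM, the lowest of the three numbers, and its gaps to compound 1 and to compound 2 both lie beyond the usual scatter of repeated measurements.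

Compound 4, `COc1cc2c(Oc3ccc(NC(=O)/C=C/S(=O)(=O)c4ccccc4OC)cc3F)ccnc2cc1OCCCN1CCCCC1`, has not yet been measured in this assay. Going by the values given here, it is related to compound 3 by piperidin-1-yl in place of 4-methylpiperazin-1-yl on a saturated chain carbon, three bonds along the chain from an oxygen on an aromatic ring, which is the same change as the one from compound 1 to compound 2, made at the same place. The one earlier occurrence of this change, a 1.3-fold higher number from compound 1 to compound 2 (0.11 log units; within the scatter), stayed within the scatter, so the expectation is that compound 4 behaves much like compound 3. The estimated step is a 1.3-fold higher number from compound 3 to compound 4 (0.11 log units; within the scatter). Compound 4 is therefore expected to give about 560 nM in this assay. Among the compounds with values here, the estimated range for compound 4 runs from 250 nM to 1300 nM, wide enough to allow for the scatter of a single measurement added to the one earlier step.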

Compound 4, half-maximal inhibitory concentration: 980 nM
Estimate against measurement, compound 4: 1.8-fold (0.24 log units) below, and the stated range covers the measured number.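

In this assay, piperidin-1-yl in place of 4-methylpiperazin-1-yl on the second core gives a 2.3-fold higher number from compound 3 to compound 4 (0.36 log units; beyond the scatter), a modest step. Set beside the one earlier occurrence of this change, the new step does not differ from it by more than two such steps can scatter, so the compounds shown give no sign that the outcome of the change depends on the core: the same change on two cores in this assay, a 1.3-fold higher number (0.11 log units; within the scatter) from compound 1 to compound 2 and a 2.3-fold higher number (0.36 log units; beyond the scatter) from compound 3 to compound 4, 1.8-fold (0.25 log units) apart, within the scatter of two such steps. Going by these compounds alone, this does not show that the change has an identical outcome on both cores, since it rests on only two pairs in a single assay, one step lying within the scatter and the other beyond it, and it says nothing about any core other than these two.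

The compounds shown leave open what a morpholin-4-yl ring or a dimethylamino group would give in place of piperidin-1-yl on that saturated chain carbon, and whether either would fare alike on both cores. They also leave open how a longer chain carrying the same basic ring would compare with the 3-(piperidin-1-yl)propyl chain in this assay.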